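The source may report more compounds than this note shows. Statements on the series, on what has been measured and on what is new or still open speak of the compounds shown alone.

Of the compounds shown here, three built on one shared core have been tested in a functional assay on MV4-11 cells (Homo sapiens) for cytotoxicity, read by MTT assay, with a stated time of 72 h; on this read-out lower numbers stand for stronger inhibition and higher numbers for weaker inhibition. Compound 1 `CC(C)(C)c1cc(NC(=O)Nc2ccc(-c3cn4ccccc4n3)cc2)no1` gives 3.09 nM. Compound 2 `CC(C)(C)c1cc(NC(=O)Nc2ccc(-c3cn4ccc(Br)cc4n3)cc2)no1`, carrying bromo in place of hydrogen on an aromatic carbon, gives 9.59 nM, which is a 3.1-fold higher number from compound 1 to compound 2 (0.49 log units; beyond the scatter). Compound 3 `C#Cc1ccn2cc(-c3ccc(NC(=O)Nc4cc(C(C)(C)C)on4)cc3)nc2c1`, carrying ethynyl in place of hydrogen on an aromatic carbon, gives 3.46 nM; the change amounts to a 1.1-fold higher number from compound 1 to compound 3 (0.05 log units; within the scatter), and against the bromo compound it is a 2.8-fold lower number from compound 2 to compound 3 (0.44 log units; beyond the scatter).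

Compound 3 thus stands second highest of the three numbers, close to compound 1 and separated from compound 2 only by a modest gap.

Compound 4 `COc1ccn2cc(-c3ccc(NC(=O)Nc4cc(C(C)(C)C)on4)cc3)nc2c1` is the next step, not yet measured. It differs from compound 3 in one place: methoxy in place of ethynyl on an aromatic carbon. Among the measured compounds shown here, no measured step swaps methoxy into this position, so the only guide is that two different groups on this aromatic carbon, hydrogen and ethynyl, gave numbers within the scatter of each other, while bromo moved the number only modestly. A small step is therefore expected in this assay, with no clear direction.

Compound 4 is estimated at 4.5 nM, within a range of 1.5 nM to 14 nM, which would mean a step of a 1.3-fold higher number from compound 3 to compound 4 (0.11 log units; within the scatter).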

Compound 4, half-maximal inhibitory concentration in the MV4-11 assay: 2.84 nM
Estimate against measurement, compound 4: 1.6-fold (0.20 log units) above, within the range that was stated.
By their numbers in the MV4-11 assay, from the lowest: compounds 4, 1 and 3 (each within the scatter of the next); then compound 2.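

Methoxy is the third group on this aromatic carbon that sits within the scatter of the others in the MV4-11 assay: a 1.2-fold lower number from compound 3 to compound 4 (0.09 log units; within the scatter) and a 1.1-fold lower number from compound 1 to compound 4 (0.04 log units; within the scatter). So hydrogen, ethynyl and methoxy cannot be told apart in this assay, even though methoxy brings a hydrogen-bond acceptor and ethynyl brings none, while bromo stays the one group set apart, with a 3.4-fold lower number from compound 2 to compound 4 (0.53 log units; beyond the scatter). The new finding is that a swap with no readable effect in the MV4-11 assay can still separate two compounds on another measurement, since in a physicochemical assay for solubility, in phosphate buffer (a lower number here means a less soluble compound, a higher number a more soluble compound), methoxy in place of ethynyl gives a more soluble compound: the measured solubility of compound 3, 10.2 ug/mL, and of compound 4, 36.6 ug/mL, a 3.6-fold higher number (0.55 log units; beyond the scatter)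

In the physicochemical assay compound 3 gives 10.2 ug/mL and compound 4 gives 36.6 ug/mL. The compounds shown leave open how hydrogen and bromo on this aromatic carbon compare with methoxy in solubility, so the gain can be stated only against ethynyl. They also leave open whether a larger group here, such as an amine, a carboxylic acid or a longer chain, would stay as close to compounds 1, 3 and 4 in the MV4-11 assay or would finally move the number.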